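Swapping a Fluorophenyl for a Methylphenyl on Compound 2

A few compounds are considered here, and "the series" means these few. Any claim that something is new, unique, unknown or untested is made for them only; others in the source may bear on it.

Of the compounds shown here, three sharing one core have been measured in a functional assay on HL-60 cells (Homo sapiens) for antiproliferative activity, read by sulforhodamine B assay, with a stated time of 72 h; a higher number here means a weaker inhibitor, a lower number a stronger inhibitor. Compound 1 `COc1ccc(C)cc1NC(=S)N/N=C/c1ccc2ccccc2n1` reaches only the limit of this assay, > 100000 nM. Compound 2 `Fc1cccc(NC(=S)N/N=C/c2ccc3ccccc3n2)c1` gives 43800 nM, and compound 3 `FC(F)(F)c1ccccc1NC(=S)N/N=C/c1ccc2ccccc2n1` gives 13200 nM. Among the two compounds with a numerical value, compound 2 stands at the highest number, with compound 3 at a lower number by a gap that lies beyond the usual scatter; the value of compound 1 is a limit rather than a number.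

The next compound, compound 4 `Cc1ccc(NC(=S)N/N=C/c2ccc3ccccc3n2)cc1`, differs from compound 2 in one place: 4-methylphenyl in place of 3-fluorophenyl on an amide-type nitrogen. The group that leaves and the group that enters are each a single six-membered aromatic ring of carbon only, with no hydrogen-bond donors or acceptors and no net charge; only the substituent on that ring changes.

Within the data shown here, no measured pair in this set shows the same change, so the direction of the step is uncertain. Compound 4 is expected to sit near compound 2, with a step of a 1.4-fold higher number from compound 2 to compound 4 (0.14 log units; within the scatter) in this assay that may not exceed the scatter. The estimate for compound 4 is 60000 nM, within a range from 15000 nM to 200000 nM.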

Compound 4, half-maximal inhibitory concentration: 78300 nM
Compound 4: the middle estimate sits 1.3-fold (0.12 log units) below what was measured; measured number inside the range.
By their numbers in this assay, from the lowest: compound 3; then compounds 2 and 4 (each within the scatter of the next). At a limit, above all of these: compound 1.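

Among these compounds, the first comparison in this set that changes only one place is 3-fluorophenyl to 4-methylphenyl on the amide-type nitrogen, and in this assay it gives a 1.8-fold higher number from compound 2 to compound 4 (0.25 log units; within the scatter). At this position, then, a fluorine-bearing ring and a methyl-bearing ring with the same count of heavy atoms cannot be told apart by this read-out, and the change neither clearly helps nor clearly harms antiproliferative activity. The upper end of the measuring range also matters for reading this series, since one compound gives no number at all and its value is only a limit: the limit of > 100000 nM in this assay, at which 1 of the 4 values shown sits.

This single pair changes both the substituent and its numbered place on the ring, so it cannot show which of the two matters, and 4-fluorophenyl or 3-methylphenyl would separate them. It also leaves open how a plain phenyl, a 4-aminophenyl or a 4-carboxyphenyl on the same nitrogen would read in this assay, and whether any group there can move the number by more than the usual scatter.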